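Butyl in place of 4-nitrophenyl on the ring nitrogen

This account rests on a few compounds, and the source may have more. Where it says the series, first, only, none or still open, it means among the compounds named here.

Compound 1 `CSc1ccc(Cc2nn(C(C)(C)C)c(=O)c3ccccc23)cc1`: in a functional assay on aorta with Alpha-1D adrenergic receptor (Rattus norvegicus) as the target (on this read-out lower numbers stand for an effect already at smaller amounts and higher numbers for an effect only at larger amounts of compound), compound 1 gives > 100000 nM, which is a limit of the assay and not a number.
Compound 2 `CSc1ccc(Cc2nn(-c3ccccc3)c(=O)c3ccccc23)cc1`: in this assay compound 2 gives > 100000 nM, also a limit of the assay.
Compound 3 `CSc1ccc(Cc2nn(-c3ccc([N+](=O)[O-])cc3)c(=O)c3ccccc23)cc1`: in this assay compound 3 gives > 100000 nM, again a limit of the assay.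

Compound 3 thus stands at the limit, the same place as the other two; all three values sit there, as shown by the limit of > 100000 nM in this assay, at which 3 of the 3 values shown sit. Of the measured steps, a step that the two limits leave unreadable from compound 1 to compound 2, a step that the two limits leave unreadable from compound 1 to compound 3 and a step that the two limits leave unreadable from compound 2 to compound 3 bear on the change, and none of them yields a readable size, so no direction can be taken from them.

Compound 4 `CCCCn1nc(Cc2ccc(SC)cc2)c2ccccc2c1=O` differs from compound 3 in one place: butyl in place of 4-nitrophenyl on an aromatic nitrogen. A small alkyl group on that nitrogen is already represented by compound 1, which gives > 100000 nM, a limit. The expected step that the limit leaves unreadable from compound 3 to compound 4 therefore cannot be given a readable size either. Compound 4 is expected to give 200000 nM, in a range from 50000 nM to 1000000 nM, and most likely to be reported only as a limit once more.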

Compound 4, half-maximal effective concentration: > 100000 nM
Compound 4 gave a limit, no number; the forecaster's own chance of this, stated with the estimate: 85%; the middle value lies beyond the limit too.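

Compound 4 gives > 100000 nM in this assay, a limit and not a number. Its steps from compound 1, compound 2 and compound 3 cannot be read, as all these compounds sit together: the limit of > 100000 nM in this assay, at which 4 of the 4 values shown sit. The compounds shown leave open whether any group on the ring nitrogen gives a measurable effect in this assay.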